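Thioether variations on a nucleoside core and transporter binding

The source may hold more compounds than are shown below. What is called first, only, known or untested is meant among the compounds shown, and "the series" means these compounds.

Measured compounds:
Compound 1, `CCC(C)Sc1nc(N)nc2c1ncn2[C@@H]1O[C@H](CO)[C@@H](O)[C@H]1O`, gives 63100 nM in an assay on isolated protein for binding affinity to Equilibrative nucleoside transporter 1 (Homo sapiens); on this read-out lower numbers stand for stronger inhibition and higher numbers for weaker inhibition.
Compound 2, `Nc1nc(SI)c2ncn([C@@H]3O[C@H](CO)[C@@H](O)[C@H]3O)c2n1`, gives 81300 nM in this assay.
Compound 3, `OC[C@H]1O[C@@H](n2cnc3c(CSc4c(F)cccc4Cl)ncnc32)[C@H](O)[C@@H]1O`, gives 1510 nM in this assay.

Compound 3 stands lowest of the three numbers in this assay; the gaps to compound 1 and compound 2 are both beyond the scatter. Compound 4, `OC[C@H]1O[C@@H](n2cnc3c(CSc4ccc(I)cc4)ncnc32)[C@H](O)[C@@H]1O`, has not yet been measured. It differs from compound 3 in one place: 4-iodophenyl in place of 2-chloro-6-fluorophenyl on a sulfur.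

Within the data shown here, only one step between measured compounds is available, a 1.3-fold higher number from compound 1 to compound 2 (0.11 log units; within the scatter), and it concerns a different substituent on a sulfur in a different core, so it bears on the present change only loosely. Among the measured compounds shown here, that step stayed within the scatter, and no measured pair addresses the exchange of one aryl group for another on a sulfur whose other neighbours are a saturated chain carbon.

Compound 4 is therefore expected to land near compound 3, with no step beyond the scatter firmly predicted, a 1.5-fold higher number from compound 3 to compound 4 (0.16 log units; within the scatter). The estimate for compound 4 in this assay is 2200 nM, within 500 nM to 9000 nM.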

Compound 4, half-maximal inhibitory concentration: 69.2 nM
For compound 4 the middle estimate is 32-fold (1.50 log units) above the measured one; the measured number lies below the stated range.
By their numbers in this assay, from the lowest: compound 4; then compound 3; then compounds 1 and 2 (each within the scatter of the next).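

In this assay, replacing 2-chloro-6-fluorophenyl with 4-iodophenyl on a sulfur whose other neighbours are a saturated chain carbon gives a 22-fold lower number from compound 3 to compound 4 (1.34 log units; beyond the scatter), showing that the choice of aryl group at this place can move the read-out strongly. Among these compounds, the only earlier step, a 1.3-fold higher number from compound 1 to compound 2 (0.11 log units; within the scatter), stayed within the scatter and concerned a different substituent on a sulfur, so it gave no sign of a change this large. Nothing shown accounts for the size of the new step.

Chlorine and fluorine leave together as iodine enters, so these compounds do not separate the contribution of each halogen. As far as these compounds go, how a bromine, a methoxy group or a plain hydrogen in place of the iodine would read in this assay remains open.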